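This account rests on a few compounds, and the source may have more. Where it says the series, first, only, none or still open, it means among the compounds named here.

Measured compounds:
compound 1, `CCCCNC(=O)Oc1ccc(Cl)cc1C(=O)Nc1cccc(Cl)c1`: 64 h
compound 2, `CCCCCNC(=O)Oc1ccc(Cl)cc1C(=O)Nc1cccc(Cl)c1`: 64 h
compound 3, `CCCCCCCCCNC(=O)Oc1ccc(Cl)cc1C(=O)Nc1ccc(Cl)c(Cl)c1`: 64 h

These three were read in an ADME assay for metabolic stability, read by HPLC, at pH 7; a lower number here means that the compound disappears faster, a higher number that the compound lasts longer. Compound 4, `CCCCCCCCCCNC(=O)Oc1ccc(Cl)cc1C(=O)Nc1ccc(Cl)c(Cl)c1`, has not yet been measured in this assay. The change from compound 1 to compound 2 is methyl in place of hydrogen on a saturated chain carbon, four bonds along the chain from an amide-type nitrogen and it gave no change at the digits printed from compound 1 to compound 2 (within the scatter). The change from compound 3 to compound 4 is methyl in place of hydrogen on a saturated chain carbon, nine bonds along the chain from an amide-type nitrogen. It is the same kind of change, not the same: in compound 2 the methyl enters four bonds along the chain from an amide-type nitrogen, in compound 4 nine bonds along the chain from an amide-type nitrogen. The difference between the core of compound 1 and the core of compound 3 is not broken down here; their values show that compound 3 stands level with compound 1 within the scatter. Compound 4 is expected to move by no change at the digits printed from compound 3 to compound 4 (within the scatter), because no change at the digits printed from compound 1 to compound 2 (within the scatter) showed no shift and compound 3 starts from 64 h. The half-life of compound 4 in this assay is therefore estimated at 64 h, with a range from 32 h to 128 h.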

Compound 4, half-life: 64 h
Compound 4: middle estimate and measured number agree at the digits printed, and the stated range covers the measured number.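

In this assay, methyl in place of hydrogen on a saturated chain carbon gave no change at the digits printed from compound 3 to compound 4 (within the scatter), and the same kind of change on the core of compound 1 had given no change at the digits printed from compound 1 to compound 2 (within the scatter). Set side by side, the two steps show that this change read the same on both cores: the same change on two cores in this assay, no change at the digits printed (within the scatter) from compound 1 to compound 2 and no change at the digits printed (within the scatter) from compound 3 to compound 4, 1.0-fold (0.00 log units) apart, within the scatter of two such steps This does not show that the change would read the same on any further core or at any other place on the chain, since each core supplies a single step, the methyl enters four bonds along the chain from an amide-type nitrogen in one and nine bonds along in the other, and neither step shifted the half-life.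

The compounds shown leave open how a branched chain or a cyclohexyl group in place of the straight chain would read in this assay. They also leave open what a chain carrying an amine or a carboxylic acid would give there.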